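The source may hold more compounds than are shown below. What is called first, only, known or untested is meant among the compounds shown, and "the series" means these compounds.

Of the compounds shown here, three have been measured in an assay on isolated protein for inhibition of NADPH oxidase 2 (Homo sapiens), read by chemiluminescence, in the presence of a further agent that is not named here; on this read-out higher numbers stand for weaker inhibition and lower numbers for stronger inhibition. Compound 1, `CCN(CC)c1ccc(/C=C2\C(=O)N(C3CCCCC3)C(=S)N2C)c(OC)c1`, gives 1950 nM. Compound 2, `CCN(CC)c1ccc(/C=C2\C(=O)N(c3ccccc3)C(=S)N2C)c(OC)c1`, gives 1470 nM in this assay. Compound 3, `CN1C(=S)N(C2CCCCC2)C(=O)/C1=C\c1ccc(N(C)C)cc1O`, gives 2960 nM in this assay. The three numbers lie within the scatter of one another, so no order among them is read from these data.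

Compound 1 and compound 2 differ in one place: phenyl in place of cyclohexyl on an amide-type nitrogen in a ring. In this assay this step is a 1.3-fold lower number from compound 1 to compound 2 (0.12 log units; within the scatter), a small movement that does not separate the two compounds. Compound 3 carries a different core from compound 1, and the difference between the two cores is not broken down here.

Compound 4, `CN1C(=S)N(c2ccccc2)C(=O)/C1=C\c1ccc(N(C)C)cc1O`, has not been measured. It differs from compound 3 by phenyl in place of cyclohexyl on an amide-type nitrogen in a ring, the same change as made between compound 1 and compound 2, at the same place on the ring nitrogen. In this assay the step is expected to be a 1.3-fold lower number from compound 3 to compound 4 (0.11 log units; within the scatter), of about the size seen in a 1.3-fold lower number from compound 1 to compound 2 (0.12 log units; within the scatter); this expectation rests on that one earlier instance of the change, made on another core, so the range around it is kept wide. Compound 4 is estimated to give 2300 nM in this assay. The expected band for compound 4 runs from 1100 nM to 4800 nM.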

Compound 4, half-maximal inhibitory concentration: 3730 nM
For compound 4 the middle estimate is 1.6-fold (0.21 log units) below the measured one; measured number inside the range.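

In this assay, among these compounds, the new step is a 1.3-fold higher number from compound 3 to compound 4 (0.10 log units; within the scatter), and it stands beside the one earlier instance of the same change: the same change on two cores in this assay, a 1.3-fold lower number (0.12 log units; within the scatter) from compound 1 to compound 2 and a 1.3-fold higher number (0.10 log units; within the scatter) from compound 3 to compound 4, 1.7-fold (0.22 log units) apart, within the scatter of two such steps. Phenyl in place of cyclohexyl on the amide-type nitrogen in a ring therefore gives no step that can be separated from the scatter on either the core of compound 1 or the core of compound 3, and the opposite signs of the two small steps carry no weight. This does not show that a real effect of the change would carry from one core to the other, as neither step is large enough to test that, and two pairs of compounds say nothing about further cores in the series.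

Cyclohexyl and phenyl are the only groups shown on this ring nitrogen, so it remains open whether an ethyl chain, a benzyl group or a phenyl ring bearing a carboxylic acid or an amine would move the number beyond the scatter. It also remains open which of the differences between the two cores matters, if any, as no pair shown differs in only one of them.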